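Notes on compound 4: amino in place of a larger group

The source may report more compounds than this note shows. Statements on the series, on what has been measured and on what is new or still open speak of the compounds shown alone.

In a functional assay on NCI-H226 cells (Homo sapiens) for inhibition, read by MTT assay, with a stated time of 72 h (a lower number here means a stronger inhibitor of growth, a higher number a weaker inhibitor of growth), compound 2 `CN(C)/C=N/c1c(C=O)c(-c2ccc(Cl)cc2)nn1-c1ccc(Br)cc1` gives 62900 nM, the highest number of the three measured compounds. Compound 3 `CN(C)/C=N/c1cc(-c2ccc(Cl)cc2)nn1-c1ccc(Br)cc1` gives 59800 nM, which lies within the scatter of compound 2. Compound 1 `Cc1ccc(-c2nn(-c3ccc(Br)cc3)c(/N=C/N(C)C)c2C=O)cc1` gives 8200 nM, the lowest of the three.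

Compound 4 `Nc1c(C=O)c(-c2ccc(Cl)cc2)nn1-c1ccc(Br)cc1` is not yet measured. It differs from compound 2 by one nitrogen atom in place of a group of 5 heavy atoms (3 carbon, 2 nitrogen; no ring), on an aromatic carbon; the amino group sits on an aromatic carbon of a five-membered aromatic ring with 2 nitrogen, next to the ring nitrogen and next to the ring atom that bears a formyl group.

Two measured steps exist: a 7.7-fold higher number from compound 1 to compound 2 (0.88 log units; beyond the scatter), a change on a pendant aryl ring, and a 1.1-fold lower number from compound 2 to compound 3 (0.02 log units; within the scatter), removal of the formyl group from the core. Among the compounds with values here, neither touches the group exchanged here, so there is no direct precedent for this change. The formyl step shows that a change on the core itself can leave this assay unchanged. On that basis no step beyond the scatter is expected: compound 4 is estimated at 55000 nM, in the range 15000 nM to 200000 nM. This estimate corresponds to a 1.1-fold lower number from compound 2 to compound 4 (0.06 log units; within the scatter).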

Compound 4, concentration for 50% growth inhibition: 49100 nM
Compound 4: middle estimate off by 1.1-fold (0.05 log units), on the high side; the measured number falls inside the stated range.
By their numbers in this assay, from the lowest: compound 1; then compounds 4, 3 and 2 (each within the scatter of the next).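

In this assay, within the data shown here, amino in place of the larger group gives a 1.3-fold lower number from compound 2 to compound 4 (0.11 log units; within the scatter), the first reading at this position. With the 4-chlorophenyl group present, the group of 5 heavy atoms and its double bond are therefore not required to keep the number within the scatter of compound 2, and neither is the absence of a hydrogen-bond donor at this carbon. Nothing available bears on why this exchange produces no step beyond the scatter.

The compounds shown leave open whether amino behaves the same way with methyl in place of chloro on the pendant aryl ring, the change that gives a 7.7-fold higher number from compound 1 to compound 2 (0.88 log units; beyond the scatter) in this assay with the larger group present. Also open, on these data alone, is what an acetamide or a longer alkylamine chain would give on this carbon.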